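A Silicon-Bearing Substituent on the Ring Nitrogen

This account rests on a few compounds, and the source may have more. Where it says the series, first, only, none or still open, it means among the compounds named here.

Of the compounds shown here, three of this set have been measured in a functional assay on HeLa cells (Homo sapiens) for antiproliferative activity, read by MTT assay, with a stated time of 72 h; a lower number here means a stronger inhibitor, a higher number a weaker inhibitor. Compound 1, `COc1cc(CC(COCc2ccccc2)COCc2ccccc2)nc(OC)n1`, gives 3500 nM in this assay. Compound 2, `O=c1cc(CC(O)COCc2ccccc2)[nH]c(=O)[nH]1`, reaches only the assay limit, > 100000 nM. Compound 3, `Cc1c(CC(O)COCc2ccccc2)[nH]c(=O)[nH]c1=O`, likewise stands at the limit, > 100000 nM. The step from compound 2 to compound 3 is accordingly a step that the two limits leave unreadable from compound 2 to compound 3, both values sharing (the limit of > 100000 nM in this assay, at which 2 of the 3 values shown sit). Going by the values given here, compound 3 thus has no number of its own, and the one measured step that touches it carries no readable size.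

Compound 4, `Cc1c(CC(O)COCc2ccccc2)n(COCC[Si](C)(C)C)c(=O)[nH]c1=O`, differs from compound 3 by a group of 8 heavy atoms (6 carbon, 1 oxygen, 1 silicon; no ring) in place of a hydrogen atom, on an aromatic nitrogen. Among the compounds with values here, no measured step involves this change, and the only step adjoining compound 3 is unreadable. Within the data shown here, compound 1 shows that a member of the series whose ring nitrogens carry no hydrogen can give a number, 3500 nM, but no measured step connects it to compound 3. The expected step is an at least 1.6-fold lower number from compound 3 to compound 4 (0.22 log units; that floor lies within the scatter), with no direction that the data can support. Compound 4 is estimated at 60000 nM, within 10000 nM to 200000 nM, with a substantial chance that this assay again reports only a limit.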

Compound 4, half-maximal inhibitory concentration: > 100000 nM
Compound 4: a limit, no number (the forecaster's own chance of this, stated with the estimate: 55%); at least 1.6-fold (0.22 log units) between middle value and limit.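

In this assay, going by these compounds alone, compound 3 and compound 4 both stand at a limit, so no step between them can be read: the limit of > 100000 nM in this assay, at which 3 of the 4 values shown sit. The compounds shown leave open whether the group of 8 heavy atoms on the aromatic nitrogen changes the activity at all.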